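The compounds below may be only part of what the source reports. "The series", "measured", "known", "first", "only" and "open" are said of these compounds alone.

Compound 1 `c1ccc2c(c1)CN[C@@H](CN(CCCCNCc1ccncc1)[C@H]1CCCc3cccnc31)C2` gives the lowest number of the three in a functional assay on cells for antagonist activity at C-X-C chemokine receptor type 4 (Homo sapiens), read by fluorescence and calcium flux, with stated times of 25 min and 90 s (on this read-out higher numbers stand for weaker inhibition and lower numbers for stronger inhibition), at 22.7 nM. Compound 3 `c1ccc2c(c1)CN[C@@H](CN(CCCCNC1CCOCC1)[C@H]1CCCc3cccnc31)C2` sits within the scatter of it, giving 29.4 nM in this assay, while compound 2 `c1ccc2c(c1)CN[C@@H](CN(CCCCNCC1CCCCC1)[C@H]1CCCc3cccnc31)C2` gives 158 nM, and the step of a 7.0-fold higher number from compound 1 to compound 2 (0.84 log units; beyond the scatter) lies beyond the scatter. Compound 4 `c1ccc2c(c1)CN[C@@H](CN(CCCCNC1CCNCC1)[C@H]1CCCc3cccnc31)C2` carries the change (piperidin-4-yl in place of (pyridin-4-yl)methyl on an amine nitrogen). Within the data shown here, the closest precedent is a 1.3-fold higher number from compound 1 to compound 3 (0.11 log units; within the scatter), where a saturated six-membered ring with one hetero atom also replaced the (pyridin-4-yl)methyl group; the steps of a 7.0-fold higher number from compound 1 to compound 2 (0.84 log units; beyond the scatter) and a 5.4-fold lower number from compound 2 to compound 3 (0.73 log units; beyond the scatter) show that a ring without a hetero atom costs potency, which piperidin-4-yl does not lack. A step of a 1.1-fold higher number from compound 1 to compound 4 (0.06 log units; within the scatter) within the scatter is therefore expected for compound 4. Compound 4 is estimated at 26 nM (10 nM to 70 nM).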

Compound 4, half-maximal inhibitory concentration: 63.4 nM
Compound 4: the middle estimate sits 2.4-fold (0.39 log units) below what was measured; measured number inside the range.
By their numbers in this assay, from the lowest: compounds 1 and 3 (each within the scatter of the next); then compound 4; then compound 2.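

In this assay, a saturated six-membered ring with one hetero atom does not guarantee the same result at this amine nitrogen: piperidin-4-yl separates from oxan-4-yl, with a 2.2-fold higher number from compound 3 to compound 4 (0.33 log units; beyond the scatter), and from (pyridin-4-yl)methyl, with a 2.8-fold higher number from compound 1 to compound 4 (0.45 log units; beyond the scatter). It still improves on cyclohexylmethyl, with a 2.5-fold lower number from compound 2 to compound 4 (0.40 log units; beyond the scatter), and no measurement shown accounts for this order. The compounds shown leave open how a (piperidin-4-yl)methyl group, or a methyl group on the piperidine ring nitrogen, would read here.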